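This account rests on a few compounds, and the source may have more. Where it says the series, first, only, none or still open, it means among the compounds named here.

Measured values in a functional assay on MCF7 cells (Homo sapiens) for inhibition, with a stated time of 48 h; on this read-out lower numbers stand for stronger inhibition of growth and higher numbers for weaker inhibition of growth:

compound 1 `O=C(Nc1sc2c(c1C(=O)NNc1ccc(Cl)cc1)CCCCC2)NS(=O)(=O)c1ccccc1` — 8300 nM
compound 2 `CCCNC(=O)c1c(NC(=O)NS(=O)(=O)c2ccccc2)sc2c1CCCCC2` — the value is a limit of the assay, > 100000 nM
compound 3 `O=C(Nc1sc2c(c1C(=O)N1CCN(c3ccccc3)CC1)CCCCC2)NS(=O)(=O)c1ccccc1` — the value is a limit of the assay, > 100000 nM

Compound 3 stands at the upper edge of what this assay reports; its entry is a limit and not a number, the same limit of > 100000 nM in this assay, at which 2 of the 3 values shown sit, at which compound 2 also sits. Only compound 1 carries a measured number, and the step from compound 2 to compound 3 cannot be read, a step that the two limits leave unreadable from compound 2 to compound 3.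

The compound still to be measured is compound 4 `O=C(Nc1sc2c(c1C(=O)NNc1ccc(Br)cc1)CCCCC2)NS(=O)(=O)c1ccccc1`. Against compound 3 the change is ((4-bromophenyl)amino)amino in place of 4-phenylpiperazin-1-yl on a carbonyl carbon. The measured step that bears on this is an at least 12-fold higher number from compound 1 to compound 3 (1.08 log units; beyond the scatter), which runs the same change in the opposite direction, with chlorine where compound 4 has bromine. Reversing that large step, compound 4 is expected to move back from the limit towards the number shown for compound 1, an expected step of an at least 12-fold lower number from compound 3 to compound 4 (1.09 log units; beyond the scatter) in this assay. Compound 4 is estimated at 8000 nM, within the range 3000 nM to 25000 nM.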

Compound 4, concentration for 50% growth inhibition: > 100000 nM
Compound 4: only a limit was reported; the forecaster's own chance of this, stated with the estimate: 10%; middle value at least 12-fold (1.09 log units) from the limit.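

Bromo in place of chloro on an aromatic carbon gives an at least 12-fold higher number from compound 1 to compound 4 (1.08 log units; beyond the scatter) in this assay, so this halogen change alone is enough to lose the measured growth inhibition. The earlier compounds shown here changed the whole group on the carbonyl carbon, and they left open whether ((4-halophenyl)amino)amino groups as a class would keep the measured inhibition; compound 4 shows that ((4-bromophenyl)amino)amino does not. Compound 1 remains the only compound here with a measured number, and the steps among compound 2, compound 3 and compound 4 cannot be read: the limit of > 100000 nM in this assay, at which 3 of the 4 values shown sit.

Going by these compounds, what fluoro, methyl or methoxy on that aromatic carbon, or an unsubstituted phenyl, would give stays open. With one measured number, no trend along the halogens can be drawn.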